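Methoxy in place of piperidin-1-yl: stability notes

The compounds below may be only part of what the source reports. "The series", "measured", "known", "first", "only" and "open" are said of these compounds alone.

In an ADME assay on microsomes from liver (Mus musculus, strain CD-1) for metabolic stability, read by LC-MS, using NADPH, with a stated time of 60 min, tested at 1 uM (a lower number here means that the compound disappears faster, a higher number that the compound lasts longer), compound 1 (`O=[N+]([O-])c1ccccc1-c1ccc(CN2CCCC2c2ccc(N3CCCCC3)cc2)o1`) gives 0.0215 h and compound 2 (`CN(C)c1cccc(C2CCCN2Cc2ccc(-c3ccccc3[N+](=O)[O-])o2)c1`) gives 0.013 h. These two values lie within the usual scatter of each other, so compound 1 stands level with compound 2 on the present numbers.

The next compound to be read is compound 3 (`COc1ccc(C2CCCN2Cc2ccc(-c3ccccc3[N+](=O)[O-])o2)cc1`). It carries methoxy in place of piperidin-1-yl on an aromatic carbon, para to a large group (methoxy in place of piperidin-1-yl on an aromatic carbon). The rest of the structure of compound 1 is unchanged.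

Going by the values given here, no pair of measured compounds isolates a single change, so the data give no direct measure of this replacement. Among the compounds with values here, the only guide is the narrow spread of the two known values, with compound 1 at 0.0215 h and compound 2 at 0.013 h. No step beyond the scatter is therefore expected in this assay, and no direction is favoured with any confidence.

The expected change is a 1.2-fold lower number from compound 1 to compound 3 (0.08 log units; within the scatter), which is an estimate and stays within the scatter. The estimated half-life of compound 3 is 0.018 h, with an expected range of 0.008 h to 0.045 h.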

Compound 3, half-life: 0.0122 h
Compound 3: the middle estimate sits 1.5-fold (0.17 log units) above what was measured, within the range that was stated.
By their numbers in this assay, from the lowest: compounds 3, 2 and 1 (each within the scatter of the next).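

Methoxy in place of piperidin-1-yl, on an aromatic carbon and para to a large group, now has a direct reading in this assay (a 1.8-fold lower number from compound 1 to compound 3 (0.25 log units; within the scatter)), so taking away the six-membered non-aromatic ring does not separate compound 3 from compound 1 on this read-out. 4-Methoxyphenyl in place of 3-(dimethylamino)phenyl on a saturated ring carbon reads the same way (a 1.1-fold lower number from compound 2 to compound 3 (0.03 log units; within the scatter)), which leaves all three groups on the aromatic ring level with one another, with no group standing apart at this site. No measurement is available that would explain this flat result or tie it to any feature of these groups.

Going by these compounds, whether a group of another kind at this aromatic carbon, such as a carboxylic acid, a primary amine or a longer alkoxy chain, would stay level with these three remains open. Also open, on these data alone, is whether a single change elsewhere on the shared core, for example an amide in place of the nitro group, would move the half-life beyond the scatter in this assay.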